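Compound 3: swapping the acyl group on the ring nitrogen

This account rests on a few compounds, and the source may have more. Where it says the series, first, only, none or still open, it means among the compounds named here.

Measured in a functional assay on NCI-H1650 cells (Homo sapiens) for cytotoxicity, read by MTT assay, with a stated time of 72 h; a lower number here means a stronger inhibitor, a higher number a weaker inhibitor
compound 1 `COc1cc(/C=C2\CN(C)C/C(=C\c3cc(OC)c(OC)c(OC)c3)C2=O)cc(OC)c1OC` gives 1500 nM
compound 2 `CCC(=O)N1C/C(=C\c2cc(OC)c(OC)c(OC)c2)C(=O)/C(=C/c2cc(OC)c(OC)c(OC)c2)C1` gives 4400 nM

Among the compounds with values here, compound 2 holds the higher of these two numbers, and compound 1 is its only neighbour. In compound 3 `COc1cc(/C=C2\CN(C(=O)c3ccccc3F)C/C(=C\c3cc(OC)c(OC)c(OC)c3)C2=O)cc(OC)c1OC` the shared core stays, and the change is 2-fluorophenyl in place of ethyl on a carbonyl carbon and nothing else. Within the data shown here, only one measured step bears on this, and it is modest: a 2.9-fold higher number from compound 1 to compound 2 (0.47 log units; beyond the scatter) with propanoyl in place of methyl on an amine nitrogen in a ring. Among the measured compounds shown here, no measured step exchanges one group on the carbonyl carbon for another, so no firm direction follows. Going by these compounds, a step within the scatter is therefore expected in this assay and the estimate is a 1.5-fold lower number from compound 2 to compound 3 (0.17 log units; within the scatter) with either direction still open. Compound 3 is expected at 3000 nM as the estimated middle of a range from 1000 nM to 9000 nM in this estimate.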

Compound 3, half-maximal inhibitory concentration: 1900 nM
For compound 3 the middle estimate is 1.6-fold (0.20 log units) above the measured one, within the range that was stated.
By their numbers in this assay, from the lowest: compounds 1 and 3 (each within the scatter of the next); then compound 2.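

With 2-fluorophenyl in place of ethyl on the carbonyl carbon, this assay shows a 2.3-fold lower number from compound 2 to compound 3 (0.36 log units; beyond the scatter), so the group carried by this carbonyl carbon affects the result. Placing a carbonyl on the ring nitrogen therefore does not by itself give a higher number: (2-fluorophenyl)carbonyl in place of methyl gives a 1.3-fold higher number from compound 1 to compound 3 (0.10 log units; within the scatter), which leaves compound 1 and compound 3 not separated.

Going by these compounds, it remains open whether plain phenyl or a morpholine on this carbonyl carbon would behave like 2-fluorophenyl. No evidence is available to explain these steps.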